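The source may hold more compounds than are shown below. What is called first, only, known or untested is meant among the compounds shown, and "the series" means these compounds.

Measured in a functional assay on PC-3 cells (Homo sapiens) for cytotoxicity, read by MTT assay, with a stated time of 72 h; on this read-out lower numbers stand for stronger inhibition and higher numbers for weaker inhibition
- compound 1 `N#Cc1ccc(/C=N/NC(=O)Nc2cc3c(Nc4ccc(F)c(Cl)c4)ncnc3cc2O[C@H]2CCOC2)cc1` gives 28100 nM
- compound 2 `COc1cc(/C=N/NC(=O)Nc2cc3c(Nc4ccc(F)c(Cl)c4)ncnc3cc2O[C@H]2CCOC2)cc(OC)c1OC` gives 29600 nM

Among the measured compounds shown here, compound 2 stands level with compound 1, the only other measured compound (a 1.1-fold higher number from compound 1 to compound 2 (0.02 log units; within the scatter)). Compound 3 `CCN(CC)c1ccc(/C=N/NC(=O)Nc2cc3c(Nc4ccc(F)c(Cl)c4)ncnc3cc2O[C@H]2CCOC2)c(O)c1` carries 4-(diethylamino)-2-hydroxyphenyl in place of 3,4,5-trimethoxyphenyl on a carbon with a double bond to nitrogen. For the measured compounds named here, that one measured step, at the same place, is the only guide, and it stays within the scatter. Going by the values given here, no measured compound carries the entering group, so the range is kept wide. The expected change is none beyond the scatter (a 1.3-fold lower number from compound 2 to compound 3 (0.13 log units; within the scatter)). The estimate for compound 3 is 22000 nM (expected range 7000 nM to 60000 nM).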

Compound 3, half-maximal inhibitory concentration: 4590 nM
For compound 3 the middle estimate is 4.8-fold (0.68 log units) above the measured one; the measured number lies below the stated range.
By their numbers in this assay, from the lowest: compound 3; then compounds 1 and 2 (each within the scatter of the next).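

In this assay the position on a carbon with a double bond to nitrogen proves able to shift the number, which the earlier exchange, a 1.1-fold higher number from compound 1 to compound 2 (0.02 log units; within the scatter), did not show. 4-(Diethylamino)-2-hydroxyphenyl gives a 6.4-fold lower number from compound 2 to compound 3 (0.81 log units; beyond the scatter) and a 6.1-fold lower number from compound 1 to compound 3 (0.79 log units; beyond the scatter), so the same lowering appears against both earlier groups. Nothing at hand accounts for this drop.

Open, on these data alone, is whether the diethylamino group, the hydroxyl or the two together carry the drop. A phenyl with the hydroxyl alone, or with a dimethylamino or a pyrrolidine group in place of diethylamino, would separate these.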